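Nitro-to-bromo swap on the sulfonyl aryl ring

This account rests on a few compounds, and the source may have more. Where it says the series, first, only, none or still open, it means among the compounds named here.

Working notes on the chromenone series. In a functional assay on SUP-B15 cells (Homo sapiens) for antiproliferative activity, with a stated time of 72 h (on this read-out higher numbers stand for an effect only at larger amounts of compound and lower numbers for an effect already at smaller amounts), compound 1 `COC(=O)c1cc(=O)c2c(OC)cc(OC)cc2n1S(=O)(=O)c1ccc(C)cc1` gives 9700 nM. Compound 2 `COc1ccc(-c2cc(=O)c3c(OC)cc(OC)cc3n2S(=O)(=O)c2cccc([N+](=O)[O-])c2)cc1` carries a methoxyphenyl instead of the ester and a nitrophenylsulfonyl instead of the tolylsulfonyl group. For compound 2 this assay returns only a limit, > 39600 nM, which is not a number; it records that no half-maximal effect was reached within the tested range (the limit of > 39600 nM in this assay, at which 1 of the 2 values shown sits). Going by the values given here, no measured pair differing in one place exists, so no step is available.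

Compound 3 `COc1ccc(-c2cc(=O)c3c(OC)cc(OC)cc3n2S(=O)(=O)c2cccc(Br)c2)cc1` differs from compound 2 by bromo in place of nitro on an aromatic carbon. Among the compounds with values here, with no measured step to lean on, no change beyond the usual scatter is expected from this exchange, and the estimated step of an at least 1.3-fold lower number from compound 2 to compound 3 (0.12 log units; that floor lies within the scatter) reflects that. Compound 3 is expected at about 30000 nM, with a range of 8000 nM to 100000 nM, and a fair chance that this assay again returns only a limit.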

Compound 3, half-maximal effective concentration: > 58600 nM
Compound 3: no number, only a limit; the forecaster's own chance of this, stated with the estimate: 50%; middle value at least 1.9-fold (0.29 log units) from the limit.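

In this assay compound 3 returns only a limit (> 58600 nM). Compound 2 also stands only as a limit (> 39600 nM), so no step can be read between these two compounds. The compounds shown leave open whether in this assay bromo in place of nitro on an aromatic carbon changes the value at all.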